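A Methyl Added to a Compound Already at the Limit

The compounds below may be only part of what the source reports. "The series", "measured", "known", "first", "only" and "open" are said of these compounds alone.

Three compounds have been tested in a functional assay on MCF7 cells (Homo sapiens) for antiproliferative activity, read by MTT assay, with a stated time of 72 h; on this read-out lower numbers stand for stronger inhibition and higher numbers for weaker inhibition:

Compound 1, `COc1ccc(N2C(=O)COc3ccc(-c4cnc5ccccc5c4)cc32)cc1`, gives > 40000 nM.
Compound 2, `O=C1COc2ccc(-c3cccc(NS(=O)(=O)c4ccc(F)cc4)c3)cc2N1c1ccccc1`, gives > 40000 nM.
Compound 3, `O=C1COc2ccc(-c3ccc(O)cc3)cc2N1`, gives > 40000 nM.

Each of these values is a limit of the assay, not a measured number. Among the measured compounds shown here, compound 2 thus stands at the limit of > 40000 nM in this assay, at which 3 of the 3 values shown sit, and since no two measured compounds differ in one place, no step size is known from the data.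

Compound 4, `Cc1ccc(N2C(=O)COc3ccc(-c4cccc(NS(=O)(=O)c5ccc(F)cc5)c4)cc32)cc1`, differs from compound 2 by methyl in place of hydrogen on an aromatic carbon. Because all three values shown sit at the limit of > 40000 nM in this assay, at which 3 of the 3 values shown sit, the step of a number no higher from compound 2 to compound 4 (the limit leaves the size open) is expected to be none beyond the scatter. Compound 4 is therefore estimated at 40000 nM, within 15000 nM to 100000 nM, and most likely reported again only as a limit.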

Compound 4, half-maximal inhibitory concentration: 32100 nM
The estimate for compound 4 lay 1.2-fold (0.10 log units) above the measured number; the range from low to high includes it.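

Among the compounds shown here, with methyl on the ring, the phenyl group having become 4-methylphenyl, compound 4 gives 32100 nM in this assay, the first value that is an actual number. Compound 2 remains a limit of the assay, at > 40000 nM. The change therefore reads only as an at least 1.2-fold lower number from compound 2 to compound 4 (0.09 log units; that floor lies within the scatter), so a real effect of the methyl is not shown, and its true size stays open.

From the compounds shown here alone, it remains open how an ethyl group or an amine would read at this same place.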